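This account rests on a few compounds, and the source may have more. Where it says the series, first, only, none or still open, it means among the compounds named here.

Measured compounds:
- compound 1, `CCOC(=O)c1sc(-c2cccc(NC(=O)c3ccc(F)cc3)c2)nc1Nc1ccc(N2CCN(C)CC2)cc1` — "not determined" (no result reported) in a functional assay on Raji cells (Homo sapiens) for antiproliferative activity, read by CCK-8 assay, with a stated time of 72 h; a higher number here means a weaker inhibitor, a lower number a stronger inhibitor
- compound 2, `CCOC(=O)c1sc(-c2cccc(NC(=O)c3cccc(F)c3)c2)nc1Nc1ccc(N2CCN(C)CC2)cc1` — 21200 nM in this assay

For the measured compounds named here, compound 1 carries its fluorine at a different position of the benzamide ring and was run without a number being reported, so compound 2 supplies the only value here. In this assay compound 2 gives 21200 nM, a high number on a scale where a higher number means a weaker inhibitor.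

Compound 3, `CCOC(=O)c1sc(-c2cccc(NC(=O)c3ccco3)c2)nc1Nc1ccc(N2CCN(C)CC2)cc1`, differs from compound 2 in one place: furan-2-yl in place of 3-fluorophenyl on a carbonyl carbon. Going by the values given here, no pair of measured compounds shows what such an exchange does to the numbers, so nothing measured points either way. The expectation is therefore a step of about a 1.2-fold higher number from compound 2 to compound 3 (0.07 log units; within the scatter), which is no larger than the ordinary scatter of repeated runs and carries no clear direction. On that basis compound 3 is estimated at 25000 nM in this assay, with a plausible range from 8000 nM to 80000 nM.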

Compound 3, half-maximal inhibitory concentration: 15100 nM
The estimate for compound 3 lay 1.7-fold (0.22 log units) above the measured number, and the stated range covers the measured number.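

In this assay, for the compounds shown here, furan-2-yl in place of 3-fluorophenyl on the carbonyl carbon gives a 1.4-fold lower number from compound 2 to compound 3 (0.15 log units; within the scatter), the first step with a number at both ends. At this position, then, a five-membered aromatic ring with one oxygen and a six-membered carbon ring bearing fluorine cannot be told apart by this read-out, and both compounds sit high on a scale where high means weak. Nothing available offers an explanation for this result.

One exchange at one position says little about how far the number can move there. On these data alone, whether a pyridine ring, a cyclohexyl ring or a plain butyl chain on the same carbonyl carbon would shift the number beyond the scatter remains open.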